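Phosphate on the hydroxymethyl across two nucleoside bases

This account rests on a few compounds, and the source may have more. Where it says the series, first, only, none or still open, it means among the compounds named here.

The series is read in a functional assay on L1210 cells (Mus musculus) for cytotoxicity; on this read-out lower numbers stand for stronger inhibition and higher numbers for weaker inhibition. Compound 1 `Cc1c2cc[n+](C)cc2c(C)c2c3c([nH]c12)C=CC(=O)[C@@]31O[C@@H]2[C@H](O1)[C@@H](CO)O[C@H]2n1ccc(N)nc1=O` gives 3 uM in this assay. Compound 2 `Cc1c2cc[n+](C)cc2c(C)c2c3c([nH]c12)C=CC(=O)[C@@]31O[C@@H]2[C@H](O1)[C@@H](COP(=O)(O)O)O[C@H]2n1ccc(N)nc1=O` carries the change a group of 4 heavy atoms (3 oxygen, 1 phosphorus; no ring) in place of a hydrogen atom, on an oxygen on a saturated carbon and gives 12.8 uM in this assay, so the step of a 4.3-fold higher number from compound 1 to compound 2 (0.63 log units; beyond the scatter) results. Compound 3 `Cc1c2cc[n+](C)cc2c(C)c2c3c([nH]c12)C=CC(=O)[C@@]31O[C@@H]2[C@H](O1)[C@@H](CO)O[C@H]2n1ccc(=O)[nH]c1=O` differs from compound 1 in its core by a group of 8 heavy atoms (4 carbon, 2 nitrogen, 2 oxygen; one six-membered aromatic ring with 2 hetero atoms) in place of a group of 8 heavy atoms (4 carbon, 3 nitrogen, 1 oxygen; one six-membered aromatic ring with 2 hetero atoms), on a saturated ring carbon. In this assay compound 3 gives > 3 uM, which is a limit of the assay and not a number. The step of a number no lower from compound 1 to compound 3 (the limit leaves the size open) follows, with compound 3 sitting at the limit of > 3 uM in this assay, at which 1 of the 3 values shown sits.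

Compound 4 `Cc1c2cc[n+](C)cc2c(C)c2c3c([nH]c12)C=CC(=O)[C@@]31O[C@@H]2[C@H](O1)[C@@H](COP(=O)(O)O)O[C@H]2n1ccc(=O)[nH]c1=O` has not been measured in this assay; it differs from compound 3 by a group of 4 heavy atoms (3 oxygen, 1 phosphorus; no ring) in place of a hydrogen atom, on an oxygen on a saturated carbon. Among the measured compounds shown here, this is the same change as the one made from compound 1 to compound 2, and the descriptions of the place agree word for word, so the earlier step is taken as the template. The expected step from compound 3 to compound 4 in this assay is a step that the limit leaves unreadable from compound 3 to compound 4, set beside the measured 4.3-fold higher number from compound 1 to compound 2 (0.63 log units; beyond the scatter), resting on the same group entering at the same position on the other core. With only a limit in hand for compound 3, the starting point is open, and a limit rather than a number is also likely for compound 4. Compound 4 is expected to give about 13 uM in this assay, with an estimated range from 5 uM to 40 uM.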

Compound 4, concentration for 50% inhibition: 1.1 uM
Estimate against measurement, compound 4: 12-fold (1.07 log units) above; the measured number lies below the stated range.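

In this assay the phosphate entering on an oxygen on a saturated carbon does not carry over from one core to the other: the step of an at least 2.7-fold lower number from compound 3 to compound 4 (0.43 log units; beyond the scatter) runs opposite to the earlier step on the core of compound 1, and the two are clearly apart: the same change on two cores in this assay, a 4.3-fold higher number (0.63 log units; beyond the scatter) from compound 1 to compound 2 and an at least 2.7-fold lower number (0.43 log units; beyond the scatter) from compound 3 to compound 4, at least 11-fold (1.06 log units) apart, beyond the scatter of two such steps

Read the other way round, the exchange of the nucleoside base among the two phosphates gives a 12-fold lower number from compound 2 to compound 4 (1.07 log units; beyond the scatter), which also fails to match the same exchange among the two unphosphorylated compounds: the same change on two cores in this assay, a number no lower (the limit leaves the size open) from compound 1 to compound 3 and a 12-fold lower number (1.07 log units; beyond the scatter) from compound 2 to compound 4, at least 11-fold (1.06 log units) apart, beyond the scatter of two such steps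

Compound 3 gives > 3 uM, which is a limit of the assay and not a number, so the full size of the gap stays open, and these two pairs show that the outcome of the change depends on the base in this series but give neither a cause nor a rule for any other base.

Open, from the compounds shown here alone, is whether a purine base such as adenine or guanine on the saturated ring carbon would follow the direction seen from compound 1 to compound 2 or that seen from compound 3 to compound 4. Also open, going by these compounds, is how a sulfate or a carboxylic acid would behave on each base in place of the phosphate, and what number compound 3 would give in place of its limit.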